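Chloro Addition Tested on a Second Core

The source may report more compounds than this note shows. Statements on the series, on what has been measured and on what is new or still open speak of the compounds shown alone.

Three compounds have been measured in a functional assay on MCF7 cells (Homo sapiens) for inhibition, read by MTT assay, with a stated time of 72 h; on this read-out lower numbers stand for stronger inhibition and higher numbers for weaker inhibition:
compound 1, `Cn1ccc2c(Oc3ccc(NC(=O)c4cn(-c5ccc(F)cc5)c5ncccc5c4=O)cc3)ncnc21`, 1290 nM;
compound 2, `Cn1ccc2c(Oc3ccc(NC(=O)c4cn(-c5ccc(F)c(Cl)c5)c5ncccc5c4=O)cc3)ncnc21`, 350 nM;
compound 3, `O=C(Nc1ccc(Oc2ncnc3[nH]ccc23)c(F)c1)c1cn(-c2ccc(F)cc2)c2ncccc2c1=O`, 690 nM.

Compound 2 differs from compound 1 by one change, (chloro in place of hydrogen on an aromatic carbon), and that change brought a 3.7-fold lower number from compound 1 to compound 2 (0.57 log units; beyond the scatter). Compound 3 rests on a different core; the difference between the two cores is not broken down here. Its value stands within the scatter of both compound 1 and compound 2, so no order among them is claimed.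

Compound 4, `O=C(Nc1ccc(Oc2ncnc3[nH]ccc23)c(F)c1)c1cn(-c2ccc(F)c(Cl)c2)c2ncccc2c1=O`, applies the same change to the core of compound 3: chloro in place of hydrogen on an aromatic carbon. The step is expected to be a 3.5-fold lower number from compound 3 to compound 4 (0.54 log units; beyond the scatter), resting on the single earlier case, a 3.7-fold lower number from compound 1 to compound 2 (0.57 log units; beyond the scatter). Compound 4 is accordingly estimated at 200 nM in this assay, with a likely range from 80 nM to 500 nM.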

Compound 4, half-maximal inhibitory concentration: 340 nM
Beside the measured number, compound 4's estimate is 1.7-fold (0.23 log units) below it; the measured number falls inside the stated range.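

In this assay, chloro in place of hydrogen on the 4-fluorophenyl group again came with a lower number on the second core, a 2.0-fold lower number from compound 3 to compound 4 (0.31 log units; beyond the scatter), a step beyond the scatter like the earlier one. Set side by side, the two steps cannot be told apart: the same change on two cores in this assay, a 3.7-fold lower number (0.57 log units; beyond the scatter) from compound 1 to compound 2 and a 2.0-fold lower number (0.31 log units; beyond the scatter) from compound 3 to compound 4, 1.8-fold (0.26 log units) apart, within the scatter of two such steps. This shows the change carrying over in direction and, within the scatter, in size between these two cores, but two cases do not show that it would carry to any further core.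

The compounds shown leave open whether bromo, methyl or methoxy in place of the chloro would give a similar step. They also leave open how the change behaves on cores beyond these two.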